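The compounds below may be only part of what the source reports. "The series", "measured", "known", "first", "only" and "open" are said of these compounds alone.

Compound 1 `Cc1n[nH]c(C(=O)O)c1Cc1cccc(-c2ccc(C#N)cc2)c1` gives 46% in an assay on isolated protein for inhibition of 2-Hydroxyacid oxidase 2 (Homo sapiens), tested at 10 uM (a higher number here means a stronger effect of the compound at the concentration tested, a lower number a weaker effect), the highest of the three numbers measured; compound 2 `Cc1n[nH]c(C(=O)O)c1Cc1cccc(-c2ccc(C(F)(F)F)cc2)c1` gives 30% and compound 3 `Cc1n[nH]c(C(=O)O)c1Cc1cccc(-c2ccc(C(=O)O)cc2)c1` gives 15%. The steps of a number 16 percentage points lower from compound 1 to compound 2 (beyond the scatter) and a number 31 percentage points lower from compound 1 to compound 3 (beyond the scatter) each exchange one group on an aromatic carbon for another, as does a number 15 percentage points lower from compound 2 to compound 3 (beyond the scatter). For the measured compounds named here, compound 4 `Cc1n[nH]c(C(=O)O)c1Cc1cccc(OC(F)(F)F)c1` differs from compound 1 in another way: trifluoromethoxy in place of 4-cyanophenyl on an aromatic carbon A group carrying a six-membered aromatic ring leaves and a group with no ring enters, so none of the measured steps bears on this change directly; they show only that what sits on that carbon matters, compound 1 carrying the group with the highest number. Compound 4 is therefore expected to lie lower, by a number 26 percentage points lower from compound 1 to compound 4 (beyond the scatter). Compound 4 is estimated at 20%, between 5% and 40%.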

Compound 4, a percentage reported as inhibition, at one concentration (the size of the read-out at that concentration, not a potency): 26%
Beside the measured number, compound 4's estimate is 6 percentage points below it; the range from low to high includes it.
By their numbers in this assay, from the lowest: compound 3; then compounds 4 and 2 (each within the scatter of the next); then compound 1.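

In this assay, this position tolerates the loss of the 4-cyanophenyl group: trifluoromethoxy in its place gives a number 20 percentage points lower from compound 1 to compound 4 (beyond the scatter), so an outer aromatic ring is not required for a measurable read-out. Compound 4, at 26%, lies within the scatter of compound 2, at 30%, so a group with no ring does as well here as that ring-bearing group. Nothing available accounts for this step. On these data alone, whether the ring or its nitrile gives compound 1 its higher number stays open, as does how an unsubstituted phenyl, a methoxy group or an amine would read here.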